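The source may report more compounds than this note shows. Statements on the series, on what has been measured and on what is new or still open speak of the compounds shown alone.

Three compounds have been measured so far in a functional assay (a lower number here means a stronger inhibitor, a higher number a weaker inhibitor), and give these values
- Compound 1 `CC(C)=CCOc1ccc2c(c1)OC(c1ccc(Cl)cc1)CC2=O` gives 6970 nM
- Compound 2 `CC(C)=CCOc1cc(O)c2c(c1)OC(c1ccccc1Cl)CC2=O` gives 4270 nM
- Compound 3 `CC(C)=CCOc1cc(O)c2c(c1)OC(c1ccc(Cl)cc1)CC2=O` gives 7020 nM

The step of a 1.0-fold higher number from compound 1 to compound 3 (0.00 log units; within the scatter) and the step of a 1.6-fold higher number from compound 2 to compound 3 (0.22 log units; within the scatter) both stay within the scatter, so compound 3 cannot be told apart from the other two on these numbers.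

The next compound, compound 4 `COc1ccc(C2CC(=O)c3c(O)cc(OCC=C(C)C)cc3O2)cc1`, differs from compound 3 in one place. It has methoxy in place of chloro on an aromatic carbon, para to a large group (methoxy in place of chloro on an aromatic carbon), which also reads as 4-chlorophenyl to 4-methoxyphenyl.

Going by the values given here, no measured pair makes this swap, so the evidence is indirect. The nearest guide is the step of a 1.6-fold higher number from compound 2 to compound 3 (0.22 log units; within the scatter) on the same aromatic ring, where 4-chlorophenyl replaces 2-chlorophenyl. The hydroxy step a 1.0-fold higher number from compound 1 to compound 3 (0.00 log units; within the scatter) concerns the core instead. Neither step leaves the scatter, so nothing here points to a change in either direction.

The expected change, a 1.2-fold lower number from compound 3 to compound 4 (0.07 log units; within the scatter) in this assay, is therefore estimated to stay within the scatter. The expected value for compound 4 is 6000 nM within an estimated range of 2500 nM to 14000 nM on this evidence.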

Compound 4, half-maximal inhibitory concentration: 5080 nM
Beside the measured number, compound 4's estimate is 1.2-fold (0.07 log units) above it; measured number inside the range.
By their numbers in this assay, from the lowest: compounds 2, 4, 1 and 3 (each within the scatter of the next).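

In this assay, putting methoxy in place of chloro on this aromatic carbon gives a 1.4-fold lower number from compound 3 to compound 4 (0.14 log units; within the scatter). The earlier compounds shown here only compared two placements of chlorine on this ring, whereas this step changes the group itself, swapping one heavy atom for two and adding a hydrogen-bond acceptor, and the number still cannot be told apart from that of compound 3. The comparison with the 2-chlorophenyl compound, a 1.2-fold higher number from compound 2 to compound 4 (0.08 log units; within the scatter), also stays within the scatter, so compounds 2, 3 and 4 show no readable difference among these three ring arrangements, and nothing measured on these compounds offers an explanation for that.

As far as these compounds go, all the substituents compared on this ring so far are chloro or methoxy, so it remains open whether an amine or a carboxylic acid at the same place would move the number beyond the scatter. From the compounds shown here alone, it also remains open whether this position can affect inhibition at all, or whether a larger change, such as a longer chain in place of the methoxy, would be needed to reveal any effect.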